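Boronic acid isomers on two aminopyridine-type cores

This account rests on a few compounds, and the source may have more. Where it says the series, first, only, none or still open, it means among the compounds named here.

Measured so far:
compound 1, `CN(Cc1cccc(B(O)O)c1)c1ccc(C(=O)Nc2ccc(F)cc2)cn1`: 4100 nM
compound 2, `CN(Cc1ccc(B(O)O)cc1)c1ccc(C(=O)Nc2ccc(F)cc2)cn1`: 1400 nM
compound 3, `O=C(Nc1ccc(F)cc1)c1cnc(NCc2cccc(B(O)O)c2)nc1`: 1340 nM

All three compounds were tested in a functional assay on RBL cells for antagonist activity at C-X-C chemokine receptor type 1 (Homo sapiens), read by fluorescence and calcium flux, with a stated time of 30 min; a lower number here means a stronger inhibitor, a higher number a weaker inhibitor. Compound 1 and compound 2 share one core and differ only in the boronic acid-bearing group: a group of 9 heavy atoms (6 carbon, 1 boron, 2 oxygen; one six-membered aromatic ring of carbon only) in place of a group of 9 heavy atoms (6 carbon, 1 boron, 2 oxygen; one six-membered aromatic ring of carbon only), on a saturated chain carbon bound to a nitrogen on an aromatic ring. That change gave a 2.9-fold lower number from compound 1 to compound 2 (0.47 log units; beyond the scatter). Compound 3 carries a different core; the difference between the two cores is not broken down here. In this assay compound 3 gives 1340 nM, which sits within the scatter of compound 2, so no order can be read between those two, while compound 1 sits a step beyond both.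

Compound 4, `O=C(Nc1ccc(F)cc1)c1cnc(NCc2ccc(B(O)O)cc2)nc1`, has not been measured. It relates to compound 3 as compound 2 relates to compound 1: a group of 9 heavy atoms (6 carbon, 1 boron, 2 oxygen; one six-membered aromatic ring of carbon only) in place of a group of 9 heavy atoms (6 carbon, 1 boron, 2 oxygen; one six-membered aromatic ring of carbon only), on a saturated chain carbon bound to a nitrogen on an aromatic ring. The place of the change is the same, on a saturated chain carbon bound to a nitrogen on an aromatic ring, so it is the same change, carried on the core of compound 3 instead of the core of compound 1.

Among the measured compounds shown here, the step is expected to run in the same direction, since the one measured instance gave a 2.9-fold lower number from compound 1 to compound 2 (0.47 log units; beyond the scatter). A somewhat smaller step is estimated for compound 4, a 2.4-fold lower number from compound 3 to compound 4 (0.39 log units; beyond the scatter). For the measured compounds named here, only one prior instance of this change exists, and it sits on a different core. Compound 4 is therefore estimated at 550 nM in this assay, with a range from 200 nM to 1500 nM.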

Compound 4, half-maximal inhibitory concentration: 1700 nM
Beside the measured number, compound 4's estimate is 3.1-fold (0.49 log units) below it; measured number outside the range, above it.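

In this assay, the same exchange of boronic acid-bearing groups on the core of compound 3 gives a 1.3-fold higher number from compound 3 to compound 4 (0.10 log units; within the scatter), so the drop in the number seen on the core of compound 1 does not recur on this core. The two steps differ when set side by side: the same change on two cores in this assay, a 2.9-fold lower number (0.47 log units; beyond the scatter) from compound 1 to compound 2 and a 1.3-fold higher number (0.10 log units; within the scatter) from compound 3 to compound 4, 3.7-fold (0.57 log units) apart, beyond the scatter of two such steps

Among the compounds shown here, in these four compounds, the effect of this change therefore does not carry from one core to the other, and the step on one core gives no safe estimate of the step on the other, though with a single pair on each core this shows only that the two steps differ, not which part of the difference between the cores is responsible or how the change would behave on a third core.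

Going by these compounds, it remains open whether a compound carrying only part of the difference between the two cores would follow the step to compound 2 or the step to compound 4. On these data alone, it is also open whether the same dependence on the core would appear with a carboxylic acid in place of the boronic acid, or with a longer chain in place of the single saturated chain carbon.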